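From an Unreported Analogue to a Chlorinated One

The source may hold more compounds than are shown below. What is called first, only, known or untested is meant among the compounds shown, and "the series" means these compounds.

The account starts with two compounds tested in a functional assay on MDA-MB-231 cells (Homo sapiens) for cytotoxicity, read by MTT assay, with a stated time of 72 h (on this read-out lower numbers stand for stronger inhibition and higher numbers for weaker inhibition), compound 1 (`Nc1ccccc1NC(=O)c1ccc(NC(=S)NCc2ccccc2F)cc1`) and compound 2 (`Nc1ccccc1NC(=O)c1ccc(NC(=S)NCc2cccnc2)cc1`). Compound 1 gives > 100000 nM, which is a limit of the assay and not a number. For compound 2 the entry reads "not determined" (no result reported), so compound 2 has no place of its own on the scale. Compound 1 therefore supplies the only reference, (the limit of > 100000 nM in this assay, at which 1 of the 2 values shown sits).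

A further analogue, compound 3 (`Nc1ccccc1NC(=O)c1ccc(NC(=S)NCc2cccc(Cl)c2)cc1`), still awaits measurement. The structural change is 3-chlorophenyl in place of pyridin-3-yl on a saturated chain carbon bound to an amide-type nitrogen.

Within the data shown here, with no number for compound 2, no step from it can be sized in this assay. Among the measured compounds shown here, the expectation is only that compound 3 will remain weak, with no large gain in inhibition, and will read close to the limit seen for compound 1. That expectation rests on compound 1 alone, whose limit is > 100000 nM. Compound 3 is expected at about 60000 nM, with an estimated range of 15000 nM to 150000 nM.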

Compound 3, half-maximal inhibitory concentration: 92000 nM
Compound 3: middle estimate off by 1.5-fold (0.19 log units), on the low side; the range from low to high includes it.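

Compound 3 gives this series its first number in this assay: with 3-chlorophenyl on the saturated chain carbon bound to an amide-type nitrogen, compound 3 reads 92000 nM, so this change yields a value on the scale, though still a high one. Replacing 2-fluorophenyl with 3-chlorophenyl gives an at least 1.0-fold lower number from compound 1 to compound 3 (0.03 log units; that floor lies within the scatter), so the two groups show no separation beyond the usual scatter, although the true size of the step remains unfixed. Any comparison at this position is still constrained by the top of the scale: the limit of > 100000 nM in this assay, at which 1 of the 3 values shown sits.

As far as these compounds go, with no result for compound 2, the steps involving pyridin-3-yl cannot be read, and the effect of that ring at this position remains unknown in this assay. The compounds shown also leave open whether a benzyl group carrying an amine or a carboxylic acid, or a longer chain in place of the single carbon of the benzyl group, would bring the value down to where differences between analogues could be sized.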